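Oxolan-2-yl in place of thiazolyl on the shared core

This account rests on a few compounds, and the source may have more. Where it says the series, first, only, none or still open, it means among the compounds named here.

In an assay on isolated protein for inhibition of Dihydrofolate reductase (Homo sapiens), read by spectrophotometry, using NADPH, with a stated time of 10 min (a higher number here means a weaker inhibitor, a lower number a stronger inhibitor), compound 1 `Cc1cc2nc(-c3nccs3)n(-c3ccc4c(N)nc(N)nc4c3)c2cc1C` gives 93 nM, the lowest of the two numbers shown. Compound 2 `COc1ccc(-c2nc3cc(C)c(C)cc3n2-c2ccc3c(N)nc(N)nc3c2)cc1` gives 2300 nM, a step of a 25-fold higher number from compound 1 to compound 2 (1.39 log units; beyond the scatter). Compound 3 `Cc1cc2nc(C3CCOC3)n(-c3ccc4c(N)nc(N)nc4c3)c2cc1C` reaches only the limit > 5000 nM in this assay, not a number. Its steps are an at least 53-fold higher number from compound 1 to compound 3 (1.73 log units; beyond the scatter) and an at least 2.1-fold higher number from compound 2 to compound 3 (0.33 log units; beyond the scatter), with one value sitting at the limit of > 5000 nM in this assay, at which 1 of the 3 values shown sits. Compound 4 `Cc1cc2nc(C3CCCO3)n(-c3ccc4c(N)nc(N)nc4c3)c2cc1C` differs from compound 1 by oxolan-2-yl in place of 1,3-thiazol-2-yl on an aromatic carbon. Both earlier exchanges of the 1,3-thiazol-2-yl, for 4-methoxyphenyl and for oxolan-3-yl, were large losses, and oxolan-2-yl is, like oxolan-3-yl, a five-membered non-aromatic ring, so a large rise in this assay is expected, probably reaching the limit again. Compound 4 is estimated at 5000 nM, between 1500 nM and 15000 nM. The expected step is a 54-fold higher number from compound 1 to compound 4 (1.73 log units; beyond the scatter).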

Compound 4, inhibition constant: 749 nM
Compound 4: middle estimate off by 6.7-fold (0.82 log units), on the high side, and the stated range ends above it.
By their numbers in this assay, from the lowest: compound 1; then compound 4; then compound 2. At a limit, above all of these: compound 3.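

Oxolan-2-yl and oxolan-3-yl are not interchangeable at this place: in this assay the exchange gives an at least 6.6-fold lower number from compound 3 to compound 4 (0.82 log units; beyond the scatter) as the difference between the two ring attachments. Compound 3 stands at a limit of the assay, not a number: (the limit of > 5000 nM in this assay, at which 1 of the 4 values shown sits). A non-aromatic ring can outdo 4-methoxyphenyl here, with a 3.1-fold lower number from compound 2 to compound 4 (0.49 log units; beyond the scatter) as the gain, while 1,3-thiazol-2-yl stays ahead, with an 8.1-fold higher number from compound 1 to compound 4 (0.91 log units; beyond the scatter) as the remaining gap.

Still open, from the compounds shown here alone, is how other aromatic rings, such as 1,3-oxazol-2-yl or pyridin-2-yl, would stand at this place. Also open, going by these compounds, is whether an amine on the oxolan-2-yl ring would close that gap.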